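From a methylpyridine amide to a phenethyl amide

A few compounds are considered here, and "the series" means these few. Any claim that something is new, unique, unknown or untested is made for them only; others in the source may bear on it.

Measured compounds:
- compound 1 `Cc1ccc(C(=O)Nc2cc(F)cc(CN3CCN(C(=O)C4CCCC4)[C@@H](C)C3)c2C)cn1`: 88 mL.min-1.g-1
- compound 2 `Cc1c(CN2CCN(C(=O)C3CCCC3)[C@@H](C)C2)cc(F)cc1NC(=O)CC(CCC(=O)O)c1ccccc1`: < 10 mL.min-1.g-1; 21 mL.min-1.g-1 (2 entries)

In an ADME assay on microsomes from liver (Homo sapiens) for metabolic stability (a lower number here means slower removal, a higher number faster removal of the compound), compound 1 gives 88 mL.min-1.g-1, the only single number among the compounds shown. Compound 2 gives < 10 mL.min-1.g-1; 21 mL.min-1.g-1 (2 entries) across several entries. Compound 3 `Cc1c(CN2CCN(C(=O)C3CCCC3)[C@@H](C)C2)cc(F)cc1NC(=O)CCc1ccccc1` has not yet been measured; it differs from compound 1 by phenethyl in place of 6-methylpyridin-3-yl on a carbonyl carbon. Among the measured compounds shown here, no measured pair shows this change, so its size is uncertain. The expected step in this assay from compound 1 to compound 3 is a 1.7-fold higher number from compound 1 to compound 3 (0.23 log units; within the scatter), toward faster removal. Compound 3 is therefore expected at 150 mL.min-1.g-1, within 60 mL.min-1.g-1 to 350 mL.min-1.g-1.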

Compound 3, intrinsic clearance in microsomes: 1900 mL.min-1.g-1
The estimate for compound 3 lay 13-fold (1.10 log units) below the measured number; measured number above the stated range.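

In this assay, the group on this carbonyl carbon carries great weight: phenethyl in place of 6-methylpyridin-3-yl gives a 22-fold higher number from compound 1 to compound 3 (1.33 log units; beyond the scatter), although the two groups are close in size. Among the compounds shown here, no earlier pair showed this change. Compound 2, whose chain ends in a carboxylic acid, has two entries, one of them a limit of the assay: the several entries of compound 2 in this assay, < 10 mL.min-1.g-1; 21 mL.min-1.g-1 (2 entries)

Still open, going by these compounds, is whether the rise follows the loss of the ring nitrogen or the arrival of the chain. A plain phenyl group or a 2-(6-methylpyridin-3-yl)ethyl group on the same carbonyl carbon would separate the two.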